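A few compounds are considered here, and "the series" means these few. Any claim that something is new, unique, unknown or untested is made for them only; others in the source may bear on it.

In a functional assay on cells (Erythrocyte, Rattus norvegicus) for inhibition, read by hemolysis, with a stated time of 1 h (a lower number here means a stronger inhibitor, a higher number a weaker inhibitor), compound 3 (`COc1cc(OC)c(OC)cc1/C=C/C(=O)c1ccc(F)cc1`) gives 2.22 ug/mL, which lies within the scatter of compound 1 (`COc1ccc(C(=O)/C=C/c2cc(OC)c(OC)cc2OC)cc1`) at 2.18 ug/mL and of compound 2 (`COc1cc(OC)c(OC)cc1/C=C/C(=O)c1ccc(-c2c[nH]cn2)cc1`) at 2.48 ug/mL. Compound 4 (`COc1cc(OC)c(OC)cc1/C=C/C(=O)c1ccc(Br)cc1`) remains unmeasured. Its difference is bromo in place of fluoro on an aromatic carbon. Three measured steps change the group at this same aromatic carbon: a 1.0-fold higher number from compound 1 to compound 3 (0.01 log units; within the scatter), a 1.1-fold lower number from compound 2 to compound 3 (0.05 log units; within the scatter) and a 1.1-fold higher number from compound 1 to compound 2 (0.06 log units; within the scatter). Within the data shown here, all three stay within the scatter, though no bromo compound has been measured yet. In this assay, the expected step, a 1.0-fold higher number from compound 3 to compound 4 (0.02 log units; within the scatter), is therefore none beyond the scatter, with no favoured direction. Compound 4 is estimated at 2.3 ug/mL, with an expected range from 1.5 ug/mL to 3.5 ug/mL.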

Compound 4, half-maximal inhibitory concentration: 2.3 ug/mL
The estimate for compound 4 equals the measured number at the digits printed; low and high end bracket the measured number.
By their numbers in this assay, from the lowest: compounds 1, 3, 4 and 2 (each within the scatter of the next).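

With bromo at this aromatic carbon, para to a large group, this assay still shows no separation: a 1.0-fold higher number from compound 3 to compound 4 (0.02 log units; within the scatter) and a 1.1-fold lower number from compound 2 to compound 4 (0.03 log units; within the scatter) and a 1.1-fold higher number from compound 1 to compound 4 (0.02 log units; within the scatter). Bromo thus joins fluoro, methoxy and 1H-imidazol-4-yl as a fourth group here, and all four compounds remain within the scatter of one another. No available evidence bears on why these groups read alike. From the compounds shown here alone, whether an amine or a carboxylic acid at this carbon would move the number beyond the scatter stays open, as does the effect of changes elsewhere on the shared core.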